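This account rests on a few compounds, and the source may have more. Where it says the series, first, only, none or still open, it means among the compounds named here.

Compound 1 `O=C(Nc1cc(-c2ccccc2)nn1-c1ccccc1Br)c1ccccc1` is the parent of this small set; in a functional assay on cells for positive allosteric modulation of metabotropic glutamate receptor 5 (Rattus norvegicus), read by calcium flux (on this read-out lower numbers stand for an effect already at smaller amounts and higher numbers for an effect only at larger amounts of compound), compound 1 gives 200 nM. Placing a nitro group on it gives compound 2 `O=C(Nc1cc(-c2ccccc2)nn1-c1ccccc1Br)c1ccc([N+](=O)[O-])cc1`, which in this assay gives 61 nM, and compound 3 `O=C(Nc1cc(-c2ccccc2)nn1-c1ccccc1Br)c1cccc([N+](=O)[O-])c1`, which in this assay gives 68 nM. The two additions read a 3.3-fold lower number from compound 1 to compound 2 (0.52 log units; beyond the scatter) and a 2.9-fold lower number from compound 1 to compound 3 (0.47 log units; beyond the scatter), while between the two nitro isomers there is a 1.1-fold higher number from compound 2 to compound 3 (0.05 log units; within the scatter). Compound 3 thus stands second highest of the three numbers, close to compound 2 and well apart from compound 1.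

Compound 4 `N#Cc1cccc(C(=O)Nc2cc(-c3ccccc3)nn2-c2ccccc2Br)c1` has not yet been measured. Its change from compound 3 is cyano in place of nitro on an aromatic carbon. Within the data shown here, the measured steps that bear on it are the two nitro additions from compound 1, both modest and beyond the scatter; no measured step shows a cyano group itself. Because the nitro group produced only a 2.9-fold lower number from compound 1 to compound 3 (0.47 log units; beyond the scatter), compound 4 is expected to give back part of that gain, a step of a 1.5-fold higher number from compound 3 to compound 4 (0.17 log units; within the scatter) in this assay. Compound 4 is therefore estimated at 100 nM, with a range from 45 nM to 220 nM.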

Compound 4, half-maximal effective concentration: 50 nM
The estimate for compound 4 lay 2.0-fold (0.30 log units) above the measured number; low and high end bracket the measured number.
By their numbers in this assay, from the lowest: compounds 4, 2 and 3 (each within the scatter of the next); then compound 1.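

In this assay, putting cyano in place of nitro on this aromatic carbon, with fewer heavy atoms and no oxygen entering, gives a 1.4-fold lower number from compound 3 to compound 4 (0.13 log units; within the scatter), so the gain over the parent at this place does not require a nitro group. The comparison with the other nitro isomer, a 1.2-fold lower number from compound 2 to compound 4 (0.09 log units; within the scatter), likewise separates neither compound, whereas a 4.0-fold lower number from compound 1 to compound 4 (0.60 log units; beyond the scatter) shows that cyano, like nitro at either place tested, stands clear of hydrogen. Nothing measured here explains why cyano and nitro match.

The compounds shown leave open whether an amine, a carboxylic acid or a longer chain at this place would keep these lower numbers. They also leave open how 4-cyanophenyl would compare with 3-cyanophenyl, and whether the same swap would hold on a changed core.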